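Moving the Nitrile on the Sulfonyl Ring

The source may report more compounds than this note shows. Statements on the series, on what has been measured and on what is new or still open speak of the compounds shown alone.

Compound 1 `Cc1ccc2ncc(S(=O)(=O)c3ccc(C#N)cc3)c(N3CCC(C)CC3)c2c1` was tested in an assay on isolated protein for displacement of a labelled ligand from metabotropic glutamate receptor 5 (Homo sapiens), with a stated time of 60 min, tested at 1 uM (on this read-out higher numbers stand for more inhibition at the one concentration tested (going by the name of the read-out) and lower numbers for less inhibition), and compound 1 gives 55%. A second member of the series, compound 2 `CC1CCN(c2c(S(=O)(=O)c3ccc(C#N)cc3)cnc3c(F)cccc23)CC1`, carries different substitution on the shared core, and in this assay compound 2 gives 86%, a higher number than compound 1 shows. Only these two have been measured, so compound 1 stands at the lower of the two numbers. Compound 3 `Cc1ccc2ncc(S(=O)(=O)c3cccc(C#N)c3)c(N3CCC(C)CC3)c2c1` has not yet been measured. It differs from compound 1 only in the ring attached to the sulfonyl sulfur: 3-cyanophenyl in place of 4-cyanophenyl on a sulfonyl sulfur. Within the data shown here, no measured pair shows what such a change does, so the expectation rests on this single comparison. The change is expected to lower inhibition by a step beyond the usual scatter, a number 20 percentage points lower from compound 1 to compound 3 (beyond the scatter). Compound 3 is therefore estimated to give 35% in this assay, with a range from 10% to 70%.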

Compound 3, a percentage reported as inhibition, at one concentration (the size of the read-out at that concentration, not a potency): 52%
For compound 3 the middle estimate is 17 percentage points below the measured one, and the stated range covers the measured number.
By their numbers in this assay, from the lowest: compounds 3 and 1 (each within the scatter of the next); then compound 2.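

In this assay, 3-cyanophenyl in place of 4-cyanophenyl on a sulfonyl sulfur gives a number 3 percentage points lower from compound 1 to compound 3 (within the scatter). Among these compounds, this is the first measured pair that isolates this one change, and on this read-out the two compounds cannot be told apart, so at the one concentration tested the number is level with either cyanophenyl ring on the core of compound 1. No measurement available here explains why the two read alike.

From the compounds shown here alone, it remains open whether an amine or a carboxylic acid in place of the nitrile on this ring would shift the number, and whether the same swap would read alike on the core of compound 2. A read-out at one concentration also leaves open whether a full potency measurement would separate compound 1 and compound 3.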